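From Fluoro to Methyl: Estimating Compound 4

A few compounds are considered here, and "the series" means these few. Any claim that something is new, unique, unknown or untested is made for them only; others in the source may bear on it.

Compound 3 `O=C(Nc1ccc(F)cc1)Nc1ccc(OC(=O)c2ccccc2)cc1` gives 29700 nM in a functional assay on A549 cells (Homo sapiens) for antiproliferative activity, read by MTT assay, with a stated time of 48 h (on this read-out lower numbers stand for stronger inhibition and higher numbers for weaker inhibition), the second highest of the three numbers measured; compound 2 `O=C(Nc1ccc(Cl)cc1)Nc1ccc(OC(=O)c2ccccc2)cc1` lies nearest with 24700 nM, within the scatter, and compound 1 `O=C(Nc1ccccc1)Nc1ccc(OC(=O)c2ccccc2)cc1` furthest with 81200 nM. Compound 4 `Cc1ccc(NC(=O)Nc2ccc(OC(=O)c3ccccc3)cc2)cc1` differs from compound 3 by methyl in place of fluoro on an aromatic carbon. Going by the values given here, two measured steps bear on this change: a 3.3-fold lower number from compound 1 to compound 2 (0.52 log units; beyond the scatter) and a 2.7-fold lower number from compound 1 to compound 3 (0.44 log units; beyond the scatter), both modest, while a 1.2-fold higher number from compound 2 to compound 3 (0.08 log units; within the scatter). Among the compounds with values here, no methyl analogue has been measured, so the effect of this particular group is unknown. For compound 4 the step is expected to stay within the scatter, with at most a slight lean toward a lower number, a 1.2-fold lower number from compound 3 to compound 4 (0.07 log units; within the scatter). Compound 4 is therefore estimated at 25000 nM, between 10000 nM and 60000 nM.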

Compound 4, half-maximal inhibitory concentration: 47700 nM
Compound 4: middle estimate off by 1.9-fold (0.28 log units), on the low side, within the range that was stated.
By their numbers in this assay, from the lowest: compounds 2, 3, 4 and 1 (each within the scatter of the next, the first and the last beyond it).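

Methyl is not separated from fluoro by a 1.6-fold higher number from compound 3 to compound 4 (0.21 log units; within the scatter) or from chloro by a 1.9-fold higher number from compound 2 to compound 4 (0.29 log units; within the scatter) in this series. Unlike those two halogens, it is also not clearly separated from hydrogen by a 1.7-fold lower number from compound 1 to compound 4 (0.23 log units; within the scatter) and so does not share their step beyond the scatter. Compound 4 therefore shows that a single heavy atom at this position does not by itself give a step beyond the scatter. From the compounds shown here alone, whether an amine, a methoxy group or a trifluoromethyl group here would track with the halogens or with methyl remains open. Nothing available explains the result.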